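Sulfur-linked aryl series: compound 3 to compound 4

The source may hold more compounds than are shown below. What is called first, only, known or untested is meant among the compounds shown, and "the series" means these compounds.

Measured in a functional assay on HeLa cells (Homo sapiens) for inhibition, read by CCK-8 assay, with a stated time of 72 h, tested at 8 uM (a lower number here means less inhibition of growth, a higher number more inhibition of growth at the concentration tested), so far:
Compound 1 `Cc1cc(C)cc(SCc2ccc(/C=C/C(=O)Nc3ccccc3N)cc2)c1` gives 3.39%
Compound 2 `Nc1ccccc1NC(=O)/C=C/c1ccc(CSc2ccc(Cl)cc2)cc1` gives 17.3%
Compound 3 `Nc1ccccc1NC(=O)/C=C/c1ccc(CSc2cccc(F)c2)cc1` gives 18.6%

Compound 3 at 18.6% sits level with compound 2 and clear of compound 1, as the step of a number 1.3 percentage points higher from compound 2 to compound 3 (within the scatter) and the step of a number 15.2 percentage points higher from compound 1 to compound 3 (beyond the scatter) show. Among the measured compounds shown here, the next compound is compound 4 `CCc1ccc(SCc2ccc(/C=C/C(=O)Nc3ccccc3N)cc2)cc1`, with 4-ethylphenyl in place of 3-fluorophenyl on a sulfur as the only change.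

For the measured compounds named here, no measured step introduces an ethyl group. Going by the values given here, compound 1 is the only measured compound with alkyl groups on this phenyl, and the step of a number 13.9 percentage points higher from compound 1 to compound 2 (beyond the scatter) and the step of a number 15.2 percentage points higher from compound 1 to compound 3 (beyond the scatter) both start from its low value. The exchange between the two halogen-bearing groups, a number 1.3 percentage points higher from compound 2 to compound 3 (within the scatter), moved little. With so few compounds, this is a weak guide. A partial fall toward compound 1 is expected, with the step estimated as a number 8.6 percentage points lower from compound 3 to compound 4 (within the scatter) on present evidence. For compound 4 the estimated value in this assay is 10% within an expected range of 1% to 22% at this stage.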

Compound 4, percent growth inhibition at one concentration: 20.9%
Compound 4: the middle estimate sits 10.9 percentage points below what was measured; low and high end bracket the measured number.
By their numbers in this assay, from the lowest: compound 1; then compounds 2, 3 and 4 (each within the scatter of the next).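

In this assay, an alkyl group on the phenyl attached to sulfur does not by itself go with a low number: the 4-ethylphenyl group of compound 4 stands level with the two halogen-bearing groups, with a number 2.3 percentage points higher from compound 3 to compound 4 (within the scatter) and a number 3.6 percentage points higher from compound 2 to compound 4 (within the scatter). Compound 1 is therefore the only outlier among these four compounds, with a number 17.5 percentage points higher from compound 1 to compound 4 (beyond the scatter), which ties its low value to the 3,5-dimethylphenyl group in particular and not to alkyl groups in general. Nothing available explains why the 3,5-dimethylphenyl group stands apart from the other three groups.

As far as these compounds go, whether a single methyl group on this phenyl would stand with compound 4 or with compound 1 remains open. So does whether an amine or a carboxylic acid on this phenyl would keep the level shared by compounds 2, 3 and 4.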